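The source may hold more compounds than are shown below. What is called first, only, known or untested is meant among the compounds shown, and "the series" means these compounds.

Three compounds sharing a pyridine-bearing acrylate motif were examined in an assay on a protein complex for inhibition of CDK8/Cyclin C (Homo sapiens), with a stated time of 1 h, tested at 10 uM; a lower number here means less inhibition, a higher number more inhibition at the concentration tested (going by the name of the read-out). Compound 1 `CCOC(=O)/C=C/c1ccncc1-c1ccc2c(cnn2C)c1` gives 100% in this assay. Compound 3 `CCOC(=O)/C=C/c1ccncc1-c1ccc2[nH]ccc2c1` gives 100%, level with compound 1; how the two cores differ is not broken down here. Compound 2 `O=C(/C=C/c1ccncc1-c1ccc2[nH]ccc2c1)N1CCOCC1` gives 97%. The change from compound 3 to compound 2 is morpholin-4-yl in place of ethoxy on a carbonyl carbon, and it produced a number 3 percentage points lower from compound 3 to compound 2 (within the scatter), a step within the scatter.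

Compound 4 `Cn1ncc2cc(-c3cnccc3/C=C/C(=O)N3CCOCC3)ccc21` is not yet measured. It differs from compound 1 by morpholin-4-yl in place of ethoxy on a carbonyl carbon, the same change that separates compound 2 from compound 3. Because compound 3 to compound 2 gave a number 3 percentage points lower from compound 3 to compound 2 (within the scatter), compound 4 is expected to show a step of a number 2 percentage points lower from compound 1 to compound 4 (within the scatter) from compound 1. The estimate for compound 4 in this assay is therefore 98%, with a range from 90% to 100%.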

Compound 4, a percentage reported as inhibition, at one concentration (the size of the read-out at that concentration, not a potency): 95%
Beside the measured number, compound 4's estimate is 3 percentage points above it; measured number inside the range.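

In this assay, morpholin-4-yl in place of ethoxy on a carbonyl carbon gave a number 5 percentage points lower from compound 1 to compound 4 (within the scatter). Set beside the earlier step, the change carries over from one core to the other with no difference that can be told apart: the same change on two cores in this assay, a number 3 percentage points lower (within the scatter) from compound 3 to compound 2 and a number 5 percentage points lower (within the scatter) from compound 1 to compound 4, 2 percentage points apart, within the scatter of two such steps. This does not show how the change affects potency, as the read-out is taken at one concentration only, and two cores give no rule for any other core in the series.

The compounds shown leave open how a carboxylic acid or an open-chain amine such as dimethylamino would compare on the same carbonyl carbon. Going by these compounds, whether a longer ester chain such as butoxy would match ethoxy also remains open.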